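Cinnamate esters on a shared core: a further methoxy

The source may hold more compounds than are shown below. What is called first, only, known or untested is meant among the compounds shown, and "the series" means these compounds.

Working notes on a small series around one shared core. Compound 1 has the structure `COc1ccc(/C=C/C(=O)OCc2nc(C)c(C)nc2C)cc1`. Compound 2 has the structure `COc1cccc(/C=C/C(=O)OCc2nc(C)c(C)nc2C)c1OC`. Compound 3 has the structure `COc1ccc(/C=C/C(=O)OCc2nc(C)c(C)nc2C)cc1OC`. In a functional assay on PC-12 cells (Rattus norvegicus) (on this read-out lower numbers stand for an effect already at smaller amounts and higher numbers for an effect only at larger amounts of compound), compound 1 gives only a limit, < 24000 nM. In this assay compound 2 likewise gives only a limit, < 24000 nM. In this assay compound 3 also gives only a limit, < 24000 nM. Going by the values given here, the series therefore rests on (the limit of < 24000 nM in this assay, at which 3 of the 3 values shown sit), and no compound can be placed relative to another.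

Compound 4, not yet measured, has the structure `COc1ccc(/C=C/C(=O)OCc2nc(C)c(C)nc2C)c(OC)c1OC`. It differs from compound 3 in one place: methoxy in place of hydrogen on an aromatic carbon. Among the compounds with values here, the one measured step of the same kind, a step that the two limits leave unreadable from compound 1 to compound 3, is also a methoxy in place of hydrogen on an aromatic carbon, but its size cannot be read, as both ends sit at the limit. Within the data shown here, no measured step therefore gives a direction or a size for the change from compound 3 to compound 4.

On this basis compound 4 is expected to land at about 6000 nM, within a range from 600 nM to 24000 nM. The step this estimate implies, a step that the limit leaves unreadable from compound 3 to compound 4, is no more than a guess that compound 4 stays near where the others are known to stand, quite possibly again only as a limit.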

Compound 4, half-maximal effective concentration: 719 nM
Beside the measured number, compound 4's estimate is 8.3-fold (0.92 log units) above it; the measured number falls inside the stated range.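

The steps to compound 4 from compound 3 and from compound 2 cannot be read, since compound 2 and compound 3 are each known only as a limit: the limit of < 24000 nM in this assay, at which 3 of the 4 values shown sit.

The compounds shown leave open where compound 1, compound 2 and compound 3 actually stand in this assay, and so what size or direction a further methoxy's step has.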